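The compounds below may be only part of what the source reports. "The series", "measured", "known", "first", "only" and "open" are said of these compounds alone.

In an assay on brain for displacement of a labelled ligand from 5-hydroxytryptamine receptor 4 (Cavia porcellus), with a stated time of 30 min, in the presence of a further agent that is not named here (on this read-out higher numbers stand for weaker inhibition and lower numbers for stronger inhibition), compound 1 `COc1ccc(S(=O)(=O)NCCN2CCC(CCC(=O)c3cc(Cl)c(N)cc3OC)CC2)cc1Cl` gives 22.5 nM, compound 2 `COc1cc(N)c(Cl)cc1C(=O)CCC1CCN(CCNS(=O)(=O)c2ccc3c(c2)NC(=O)CO3)CC1` gives 6.2 nM, and compound 3 `COc1ccc(S(=O)(=O)NCCN2CCC(CCC(=O)c3cc(Cl)c(N)cc3OC)CC2)cc1` gives 12.3 nM. Among these three numbers compound 3 stands second highest, and both of its neighbours lie within the usual scatter of it: compound 1 sits a 1.8-fold lower number from compound 1 to compound 3 (0.26 log units; within the scatter) away, compound 2 a 2.0-fold higher number from compound 2 to compound 3 (0.30 log units; within the scatter) away.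

Compound 4 `COc1cc(N)c(Cl)cc1C(=O)CCC1CCN(CCNS(=O)(=O)c2ccc(OC)c(N3CCN(C)CC3)c2)CC1` differs from compound 3 in one place: 4-methylpiperazin-1-yl in place of hydrogen on an aromatic carbon, on the ring attached to the sulfonyl sulfur, ortho to a methoxy group. Two of the measured steps alter that same ring. Replacing its substituents by a larger group gave a 3.6-fold lower number from compound 1 to compound 2 (0.56 log units; beyond the scatter), while removing chloro gave a 1.8-fold lower number from compound 1 to compound 3 (0.26 log units; within the scatter); the reverse of the second step, going to the plain ring, gave a 2.0-fold higher number from compound 2 to compound 3 (0.30 log units; within the scatter). These steps are modest or within the scatter, so in this assay the change to compound 4 is expected to shift the number little, at most slightly downward, as a 1.5-fold lower number from compound 3 to compound 4 (0.19 log units; within the scatter). Compound 4 is therefore estimated at 8 nM, within 3 nM to 25 nM.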

Compound 4, inhibition constant: 3.46 nM
Estimate against measurement, compound 4: 2.3-fold (0.36 log units) above, and the stated range covers the measured number.
By their numbers in this assay, from the lowest: compounds 4, 2, 3 and 1 (each within the scatter of the next, the first and the last beyond it).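

In this assay, 4-methylpiperazin-1-yl on the aromatic carbon ortho to a methoxy group gives a 3.6-fold lower number from compound 3 to compound 4 (0.55 log units; beyond the scatter), and the same group in place of chloro gives a 6.5-fold lower number from compound 1 to compound 4 (0.81 log units; beyond the scatter). Hydrogen and chloro at this position had stayed within the scatter of each other, so this is the first change here to move the number beyond the scatter, and it shows that 4-methylpiperazin-1-yl is accepted with stronger, not weaker, inhibition. Nothing given here accounts for this lower number.

The compounds shown leave open whether the whole ring is needed, which a morpholin-4-yl group, a piperidin-1-yl group or a plain dimethylamino group at this position would help to separate. Going by these compounds, the role of the methyl also stays open, and piperazin-1-yl without it would address that.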